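The compounds below may be only part of what the source reports. "The series", "measured", "known", "first", "only" and "open" are said of these compounds alone.

Compound 2 `COc1ccc(CNc2nc3cc(N)cc(N)c3nc2-c2ccccc2)cc1OC` gives 47900 nM in a functional assay on NCI-H322M cells (Homo sapiens) for inhibition, read by sulforhodamine B assay, with a stated time of 48 h (on this read-out lower numbers stand for stronger inhibition of growth and higher numbers for weaker inhibition of growth), the highest of the three numbers, though the step of a 1.6-fold higher number from compound 1 to compound 2 (0.20 log units; within the scatter) stays within the scatter. Compound 1 `Nc1cc(N)c2nc(-c3ccccc3)c(NCc3ccc(Cl)c(Cl)c3)nc2c1` gives 30200 nM, and compound 3 `COc1cc(CNc2nc3cc(N)cc(N)c3nc2-c2ccccc2)cc(OC)c1OC` gives 15800 nM. The change to compound 4 `COc1ccc(CNc2nc3cc(N)cc(N)c3nc2-c2ccccc2)cc1` is hydrogen in place of methoxy on an aromatic carbon, read one bond further out as 3,4-dimethoxyphenyl to 4-methoxyphenyl. Going by the values given here, one measured step bears directly on it: a 3.0-fold lower number from compound 2 to compound 3 (0.48 log units; beyond the scatter), where gaining a methoxy on this ring moved the number beyond the scatter. Losing a methoxy from compound 2 is therefore expected to leave the number where it is or push it somewhat higher, so the estimated step is a 1.4-fold higher number from compound 2 to compound 4 (0.13 log units; within the scatter). Compound 4 is expected to give 65000 nM, in a range from 25000 nM to 160000 nM.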

Compound 4, concentration for total growth inhibition: 52500 nM
Compound 4: the middle estimate sits 1.2-fold (0.09 log units) above what was measured; the range from low to high includes it.
By their numbers in this assay, from the lowest: compounds 3, 1, 2 and 4 (each within the scatter of the next, the first and the last beyond it).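

In this assay, removing one methoxy from the 3,4-dimethoxyphenyl group to leave 4-methoxyphenyl gives a 1.1-fold higher number from compound 2 to compound 4 (0.04 log units; within the scatter), so this methoxy can be lost without a shift beyond the scatter. The step of a 1.7-fold higher number from compound 1 to compound 4 (0.24 log units; within the scatter) shows that 4-methoxyphenyl and 3,4-dichlorophenyl also cannot be told apart here. Nothing shown explains these results. As far as these compounds go, it remains open whether an amine or a hydroxyl group at this position would move the number, and whether an ethoxy group would do so in place of the methoxy.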